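The compounds below may be only part of what the source reports. "The series", "measured", "known", "first", "only" and "open" are said of these compounds alone.

In a functional assay on A549 cells (Homo sapiens) for inhibition (a lower number here means a stronger inhibitor, a higher number a weaker inhibitor), compound 1 `O=C(CC(CC(=O)NC1Cc2ccccc2C1)c1ccccc1)NCCN1CCCC1` gives > 100000 nM as a limit and not a number. Compound 2 `CCNCCNC(=O)CC(CC(=O)N(CC)C1Cc2ccccc2C1)c1ccccc1` gives > 100000 nM and this too is only a limit. Among the compounds with values here, the series so far offers one guide: the limit of > 100000 nM in this assay, at which 2 of the 2 values shown sit, and no measured step. The change to compound 3 `CCN(C(=O)CC(CC(=O)NCCN1CCCC1)c1ccccc1)C1Cc2ccccc2C1` is pyrrolidin-1-yl in place of ethylamino on a saturated chain carbon, two bonds along the chain from an amide-type nitrogen and no measured step sizes it. No shift beyond the scatter is expected in this assay in either direction. The step of a number no higher from compound 2 to compound 3 (the limit leaves the size open) is expected to stay within the scatter. For compound 3 the estimate is 100000 nM with an expected range of 40000 nM to 200000 nM and a report of only a limit is likely.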

Compound 3, half-maximal inhibitory concentration: > 100000 nM
Compound 3 gave a limit, no number; the forecaster's own chance of this, stated with the estimate: 85%; the middle value sits exactly at the limit.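

Within the data shown here, no step to compound 3 can be read from compound 1 or compound 2, since all three compounds give only a limit in this assay. The compounds shown leave open whether any change to the shared core yields a measurable number.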